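Trading a cyclopentyl amine for a pyrrolidine ring

This account rests on a few compounds, and the source may have more. Where it says the series, first, only, none or still open, it means among the compounds named here.

Compound 1 `COc1cnc(-c2ccccn2)nc1N(C)C1CCCC1` carries a cyclopentyl(methyl)amino group on its shared core. In an in vitro ADME assay on microsomes from liver (Rattus norvegicus) for metabolic stability, read by LC-MS, tested at 0.05 uM (on this read-out higher numbers stand for fast clearance and lower numbers for slow clearance), compound 1 gives only a limit, > 1000 mL/min/kg, rather than a number. Compound 2 `COc1cnc(-c2ccccn2)nc1NC(C)c1ccccc1` shares the core and in this assay gives 420 mL/min/kg. No step between these two measured compounds is worked out here, so their two values are simply what is shown; the note the limit of > 1000 mL/min/kg in this assay, at which 1 of the 2 values shown sits, records that the value of compound 1 sits at the limit of this assay.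

Compound 3 `COc1cnc(-c2ccccn2)nc1N1CCCC1` has not yet been measured. It differs from compound 1 in one place: pyrrolidin-1-yl in place of cyclopentyl(methyl)amino on an aromatic carbon. For the measured compounds named here, since compound 1 stands only at a limit, no measured step gives a scale for this change. The expectation is that clearance in this assay falls on going from compound 1 to compound 3, by a step of an at least 2.8-fold lower number from compound 1 to compound 3 (0.45 log units; beyond the scatter), beyond the usual scatter but not by a large margin. Compound 3 is therefore estimated at 350 mL/min/kg in this assay, with a plausible range from 120 mL/min/kg to 1000 mL/min/kg.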

Compound 3, clearance: 987 mL/min/kg
Beside the measured number, compound 3's estimate is 2.8-fold (0.45 log units) below it; the measured number falls inside the stated range.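

In this assay compound 3 gives 987 mL/min/kg, a true number for a pyrrolidin-1-yl group on this aromatic carbon, and the change from cyclopentyl(methyl)amino to pyrrolidin-1-yl amounts to an at least 1.0-fold lower number from compound 1 to compound 3 (0.00 log units; that floor lies within the scatter). Compound 1 gives > 1000 mL/min/kg, which is a limit and not a number. So this result does not establish that the swap lowers clearance, and the real size of the step cannot be read, because one end of it is only a limit: the limit of > 1000 mL/min/kg in this assay, at which 1 of the 3 values shown sits.

The compounds shown leave open how far compound 1 really lies from compound 3, so the effect of folding the amine into a smaller ring remains unsized. They also leave open what other groups on this same carbon would give in this assay, such as a morpholine ring, a piperidine ring or a small open-chain dimethylamino group, any of which would show how clearance follows the shape and atoms of the amine at this position.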